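Swapping the para substituent: chloro to methyl on the aryl ring

The source may hold more compounds than are shown below. What is called first, only, known or untested is meant among the compounds shown, and "the series" means these compounds.

Measured compounds:
compound 1, `NC(=O)Nc1sc(-c2ccc(C(=O)N3CCOCC3)cc2)cc1C(=O)N[C@H]1CCCNC1` — "not determined" (no result reported) in an assay on isolated protein for inhibition of cyclin-dependent kinase 2-associated protein 1 (Homo sapiens); on this read-out lower numbers stand for stronger inhibition and higher numbers for weaker inhibition
compound 2, `CS(=O)(=O)c1ccc(-c2cc(C(=O)N[C@H]3CCCNC3)c(NC(N)=O)s2)cc1` — 2200 nM
compound 3, `NC(=O)Nc1sc(-c2ccc(Cl)cc2)cc1C(=O)N[C@H]1CCCNC1` — 3700 nM

Three compounds share a common core and differ only in the group on the pendant phenyl ring. Compound 1 carries a morpholine amide there, but in this assay no result was reported for it. Compound 2 carries a methylsulfonyl group and in this assay gives 2200 nM. Compound 3 carries a chloro group and in this assay gives 3700 nM. Among the measured compounds shown here, the only comparable step is a 1.7-fold higher number from compound 2 to compound 3 (0.23 log units; within the scatter), so compound 3 and compound 2 sit within the scatter of each other, and compound 3 has no other numbered neighbour.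

Compound 4, `Cc1ccc(-c2cc(C(=O)N[C@H]3CCCNC3)c(NC(N)=O)s2)cc1`, has not yet been measured. It differs from compound 3 by methyl in place of chloro on an aromatic carbon. For the measured compounds named here, the one step that bears on this position, from methylsulfonyl to chloro, stayed within the scatter, which suggests that this position tolerates different small groups without a large shift. Going by the values given here, with no further measured step to draw on, compound 4 is expected to give roughly 4500 nM in this assay, with a range from 1800 nM to 12000 nM. This estimate corresponds to a step of a 1.2-fold higher number from compound 3 to compound 4 (0.09 log units; within the scatter), expected to remain within the scatter.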

Compound 4, half-maximal inhibitory concentration: 5500 nM
Compound 4: middle estimate off by 1.2-fold (0.09 log units), on the low side, and the stated range covers the measured number.
By their numbers in this assay, from the lowest: compounds 2, 3 and 4 (each within the scatter of the next, the first and the last beyond it).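

In this assay the change from 4-chlorophenyl to 4-methylphenyl gives a 1.5-fold higher number from compound 3 to compound 4 (0.17 log units; within the scatter) and so cannot be told apart from no effect; chloro and methyl, each a single heavy atom with no hydrogen-bond donors or acceptors, are interchangeable here as far as this read-out can show. Among the compounds shown here, the new information lies in the other comparison: methyl in place of methylsulfonyl gives a 2.5-fold higher number from compound 2 to compound 4 (0.40 log units; beyond the scatter) and is the first step at this position to clear the scatter, though only modestly, showing that the choice of group on this aromatic carbon has some bearing on the number. Compound 3 lies within the scatter of both compound 2 and compound 4, so only the two ends of this short series separate, and nothing measured here explains that separation.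

The compounds shown leave open whether an amine, a carboxylic acid or a longer chain on this carbon would give a larger step in either direction. They also leave open how the morpholine amide of compound 1 compares with these groups in this assay.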